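The compounds below may be only part of what the source reports. "The series", "measured", "known", "first", "only" and "open" are said of these compounds alone.

Compound 1, `CS(=O)(=O)Nc1ccc(CNC(=O)CCc2ccc(Br)cc2)cc1F`, gives > 10000 nM in a functional assay (strain Sprague-Dawley) for antagonist activity at transient receptor potential cation channel subfamily V member 1 (Rattus norvegicus) (on this read-out higher numbers stand for weaker inhibition and lower numbers for stronger inhibition), which is a limit of the assay rather than a number.
Compound 2, `CC(C)(C)c1ccc(CCC(=O)NCc2ccc(NS(C)(=O)=O)c(F)c2)cc1`, gives 170 nM in this assay.
Compound 3, `CS(=O)(=O)Nc1ccc(CNC(=O)CCc2ccc(CC3CC3)cc2)cc1F`, gives 360 nM in this assay.

Among the two numbers that are not limits, compound 3 holds the higher one, with compound 2 nearest to it: a 2.1-fold higher number from compound 2 to compound 3 (0.33 log units; beyond the scatter). Compound 1 sits at the limit (the limit of > 10000 nM in this assay, at which 1 of the 3 values shown sits).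

The step considered here leads to compound 4, `CC(C)Oc1ccc(CCC(=O)NCc2ccc(NS(C)(=O)=O)c(F)c2)cc1`, which is not yet measured in this assay. The change is isopropoxy in place of cyclopropylmethyl on an aromatic carbon.

Within the data shown here, none of the measured steps exchanges a group at this position for an alkoxy group. The steps of an at least 58-fold lower number from compound 1 to compound 2 (1.76 log units; beyond the scatter) and an at least 27-fold lower number from compound 1 to compound 3 (1.44 log units; beyond the scatter) show that replacing bromo at this carbon can move the number a long way, while a 2.1-fold higher number from compound 2 to compound 3 (0.33 log units; beyond the scatter) shows a modest difference between two alkyl groups. Isopropoxy brings an oxygen acceptor that no measured compound carries, so the expectation for compound 4 is uncertain and a step of modest size in either direction is expected: a 1.7-fold higher number from compound 3 to compound 4 (0.22 log units; within the scatter).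

Compound 4 is therefore estimated at 600 nM, within a range from 150 nM to 2500 nM.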

Compound 4, half-maximal inhibitory concentration: > 10000 nM
Compound 4 was reported as a limit; the forecaster's own chance of this, stated with the estimate: 10%; at least 16-fold (1.22 log units) between middle value and limit.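

In this assay, isopropoxy on this aromatic carbon, para to a large group, does not follow the two alkyl groups that gave readable numbers: an at least 27-fold higher number from compound 3 to compound 4 (1.44 log units; beyond the scatter), and an at least 58-fold higher number from compound 2 to compound 4 (1.76 log units; beyond the scatter). The change from cyclopropylmethyl keeps the count at 4 heavy atoms, yet it replaces a carbon with an oxygen, removes the three-membered ring and adds 1 hydrogen-bond acceptor, so a swap with no change in heavy-atom count can still produce a large step here, although these differences cannot be separated. Compound 4 stands at a limit of the assay, and the step between it and compound 1, which stands at the same limit, cannot be read: the limit of > 10000 nM in this assay, at which 2 of the 4 values shown sit.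

The compounds shown leave open whether the oxygen is what matters, since an isopropyl group at this carbon would keep the branched shape without it, and a methoxy group would keep the oxygen with a shorter chain. They also leave open how a cyclopropyl group joined directly to the ring, or a cyclopropylmethoxy group, would read in this assay.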